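Ring methyl configuration: from compound 2 to compound 3

The compounds below may be only part of what the source reports. "The series", "measured", "known", "first", "only" and "open" are said of these compounds alone.

Measured so far:
compound 1 `CC(C)(C)C(=O)NCc1ccc(NC(=O)N2CCCC[C@H]2[C@@H](O)c2ccc(Cl)c(Cl)c2)cc1` — 4300 nM
compound 2 `C[C@H]1CC[C@@H]([C@@H](O)c2ccc(Cl)c(Cl)c2)N1C(=O)Nc1ccc(CNC(=O)C(C)(C)C)cc1` — 400 nM

In a functional assay for inhibition, with Homo sapiens as the target (a lower number here means a stronger inhibitor, a higher number a weaker inhibitor), compound 1 gives 4300 nM, while compound 2 gives 400 nM. Compound 2 therefore holds the lower of the two numbers, and its gap to compound 1 lies beyond the usual scatter, so compound 2 is the stronger inhibitor of the pair on the numbers at hand.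

The next compound is compound 3 `C[C@@H]1CC[C@@H]([C@@H](O)c2ccc(Cl)c(Cl)c2)N1C(=O)Nc1ccc(CNC(=O)C(C)(C)C)cc1`. Its relation to compound 2: the two compounds have the same atoms and bonds and differ only in configuration as drawn: 1 of 3 stereo elements differ; a stereocentre at a saturated ring carbon is drawn S in compound 2 and R in compound 3. The methyl group, the carbinol and the rest of the molecule are thus unchanged; only the drawn configuration at that one saturated ring carbon is inverted.

For the measured compounds named here, no pair of measured compounds differing in one place is available, so nothing measured here shows how large such an inversion is in this assay. The single configuration shown in compound 2 is the one that gives the lower number; its epimer is expected to give a higher number, with a step from compound 2 to compound 3 of a 4.0-fold higher number from compound 2 to compound 3 (0.60 log units; beyond the scatter), beyond the scatter but uncertain in size. Compound 3 is estimated at 1600 nM, within a range of 350 nM to 7000 nM.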

Compound 3, half-maximal inhibitory concentration: > 10000 nM
Compound 3 gave a limit, no number (the forecaster's own chance of this, stated with the estimate: 5%); middle value at least 6.2-fold (0.79 log units) away from the limit.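

In this assay, for the compounds shown here, inverting the drawn configuration at the methyl-bearing saturated ring carbon gives an at least 25-fold higher number from compound 2 to compound 3 (1.39 log units; beyond the scatter), a large step, and this is the first pair in which one change can be read on its own. The step can be assigned to this stereocentre alone, with no group entering or leaving, because of the following: the fact that compounds 2 and 3 differ only in the configuration as drawn. Compound 3 gives > 10000 nM, which is a limit and not a number, so the step fixes only a minimum size and the position is shown to be sensitive to configuration, with the S drawing in compound 2 the better of the two.

The compounds shown leave open whether an ethyl or a hydroxymethyl group at this ring carbon would keep the potency of compound 2 under the S drawing, or whether the methyl group itself is what matters. No compound shown has an inverted carbinol carbon or an inverted other ring stereocentre. The size of the step for either inversion is therefore unknown, and so is whether either would be as costly as this one.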